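Notes on the step from compound 3 to compound 4

A few compounds are considered here, and "the series" means these few. Any claim that something is new, unique, unknown or untested is made for them only; others in the source may bear on it.

Three compounds of the series have numbers in a functional assay on NCI-H460 cells (Homo sapiens) for cytotoxicity, read by MTT assay, with a stated time of 72 h; on this read-out lower numbers stand for stronger inhibition and higher numbers for weaker inhibition. Compound 1 `CC(C)c1[nH]cnc1/C=c1\[nH]c(=O)/c(=C/c2cccc(C(=O)c3ccc(F)cc3)c2)[nH]c1=O` gives 3.2 nM in this assay. Compound 2 `O=C(c1ccc(F)cc1)c1cccc(/C=c2\[nH]c(=O)/c(=C/c3nc[nH]c3C3CC3)[nH]c2=O)c1` gives 2.8 nM in this assay. Among the measured compounds shown here, the only single-place step measured so far is a 1.1-fold lower number from compound 1 to compound 2 (0.06 log units; within the scatter). Compound 3 `O=c1[nH]/c(=C\c2c[nH]cn2)c(=O)[nH]/c1=C\c1cccc(Oc2ccc(F)cc2)c1` gives 479 nM in this assay, the highest of the three numbers, and its gaps to compound 1 and to compound 2 both lie beyond the scatter.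

Compound 4 `O=c1[nH]/c(=C\c2ccc(Cl)o2)c(=O)[nH]/c1=C\c1cccc(Oc2ccc(F)cc2)c1` awaits measurement in this assay. It differs from compound 3 in one place: 5-chlorofuran-2-yl in place of 1H-imidazol-4-yl on a double-bonded chain carbon bound to an aromatic carbon. For the measured compounds named here, no measured step touches this position; the single step on record, a 1.1-fold lower number from compound 1 to compound 2 (0.06 log units; within the scatter), concerns a different site and stayed within the scatter, so it offers no guide to the size or direction of the present change. With nothing to anchor the step, the number for compound 4 is expected close to that of compound 3, and the step of a 1.3-fold higher number from compound 3 to compound 4 (0.10 log units; within the scatter) is estimated as lying within the scatter, with wide uncertainty around it. For compound 4 the estimate in this assay is 600 nM, with a range from 100 nM to 4000 nM.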

Compound 4, half-maximal inhibitory concentration: 180 nM
Compound 4: the middle estimate sits 3.3-fold (0.52 log units) above what was measured; measured number inside the range.
By their numbers in this assay, from the lowest: compounds 2 and 1 (each within the scatter of the next); then compound 4; then compound 3.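

In this assay, the place on a double-bonded chain carbon bound to an aromatic carbon now has its first reading: 5-chlorofuran-2-yl in place of 1H-imidazol-4-yl gives a 2.7-fold lower number from compound 3 to compound 4 (0.43 log units; beyond the scatter), a modest step beyond the scatter. The number therefore does not depend on keeping 1H-imidazol-4-yl here, since a ring with 1 hetero atom, a chlorine and 0 hydrogen-bond donors gives a lower number on this background. Nothing available ties the step to any property of either group.

The compounds shown leave open which part of the exchange carries the step, as the ring, the chlorine and the hydrogen-bond donor all change at once; a plain furan-2-yl or a 1H-imidazol-4-yl bearing a chlorine would be needed to pull these apart. Also open, from the compounds shown here alone, is whether the step holds on other backgrounds, such as the 4-fluorobenzoyl-bearing ring system of the lowest numbers, and whether a phenyl ring or an aminomethyl-substituted furan at this place would follow the same direction.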